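The source may hold more compounds than are shown below. What is called first, only, known or untested is meant among the compounds shown, and "the series" means these compounds.

Series notes: three analogues around one shared core have numbers in a functional assay on CHO-K1 cells for antagonist activity at transient receptor potential cation channel subfamily V member 1 (Homo sapiens), read by FLIPR; a higher number here means a weaker inhibitor, a lower number a stronger inhibitor. Compound 1, `CC(C(=O)NCc1ccc(C(F)(F)F)nc1N(C)C)c1ccc(NS(C)(=O)=O)c(F)c1`, gives in this assay 2390 nM. Compound 2, `CC(C(=O)NCc1ccc(C(F)(F)F)nc1N1CCC(OC(=O)C(C)(C)C)CC1)c1ccc(NS(C)(=O)=O)c(F)c1`, gives in this assay 45.2 nM. Compound 3, `CC(C(=O)NCc1ccc(C(F)(F)F)nc1N1CCN(c2ccc(C(F)(F)F)cc2)CC1)c1ccc(NS(C)(=O)=O)c(F)c1`, gives in this assay 117 nM, the second highest of the three numbers; its nearest neighbour is compound 2, whose number is lower by a gap beyond the scatter, and its furthest is compound 1, whose number is higher by a far wider gap.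

The next analogue, compound 4, `CC(C(=O)NCc1ccc(C(F)(F)F)nc1N1CCN(Cc2ccccc2)CC1)c1ccc(NS(C)(=O)=O)c(F)c1`, differs from compound 3 in one place: benzyl in place of 4-(trifluoromethyl)phenyl on an amine nitrogen in a ring. Among the compounds with values here, no measured pair in the set shows this kind of exchange, so its size must be estimated from what the three numbers suggest. The larger groups on the amine nitrogen in compound 2 and compound 3 sit well below compound 1, and benzyl keeps a full aromatic ring there, so a modest weakening is expected, a 1.9-fold higher number from compound 3 to compound 4 (0.27 log units; within the scatter), staying within or just beyond the scatter. For compound 4 the estimate in this assay is 220 nM, with a range from 60 nM to 800 nM.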

Compound 4, half-maximal inhibitory concentration: 634 nM
Compound 4: the middle estimate sits 2.9-fold (0.46 log units) below what was measured; low and high end bracket the measured number.
By their numbers in this assay, from the lowest: compound 2; then compound 3; then compound 4; then compound 1.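

In this assay, benzyl in place of 4-(trifluoromethyl)phenyl on the amine nitrogen in the ring gives a 5.4-fold higher number from compound 3 to compound 4 (0.73 log units; beyond the scatter) and so shows that this position is sensitive to which aromatic group it carries, with a retained six-membered aromatic ring of carbon only not enough to hold the number. The exchange removes trifluoromethyl and also alters how the ring is attached, and this single step cannot separate the two changes. Nothing available explains the weakening.

As far as these compounds go, whether phenyl without trifluoromethyl, or benzyl bearing trifluoromethyl, would sit nearer compound 3 or compound 4 remains open. Also open, from the compounds shown here alone, is how this nitrogen would tolerate a non-aromatic substituent such as a cyclohexyl group, a longer chain or a carboxylic acid.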